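The source may report more compounds than this note shows. Statements on the series, on what has been measured and on what is new or still open speak of the compounds shown alone.

Compound 1 `O=C(NCc1ccc(-c2noc(CCC3CC3)n2)cc1)[C@H]1NCC[C@@H]1O` gives 5000 nM in an assay on isolated protein for inhibition of sphingosine kinase 1 (Homo sapiens); a higher number here means a weaker inhibitor, a lower number a stronger inhibitor.
Compound 2 `CCCCCCCc1nc(-c2ccc([C@H](C)NC(=O)[C@H]3NCC[C@@H]3O)cc2)no1` gives 48 nM in this assay.

Of the two measured compounds, compound 1 has the higher number and is the weaker inhibitor; compound 2 lies far lower, a gap well beyond the scatter. Compound 3 `CCCCCCCCc1nc(-c2ccc(CNC(=O)[C@H]3NCC[C@@H]3O)cc2)no1` has not yet been measured. It differs from compound 1 in one place: hexyl in place of cyclopropyl on a saturated chain carbon, two bonds along the chain from an aromatic carbon. Going by the values given here, no measured pair isolates this change, but compound 2 also carries a long straight chain, a heptyl, and is expected to point the way because compound 2 gives 48 nM against compound 1 at 5000 nM. A large step toward stronger inhibition is therefore expected, estimated as a 42-fold lower number from compound 1 to compound 3 (1.62 log units; beyond the scatter) in this assay, not quite reaching compound 2 since the two still differ elsewhere. Compound 3 is expected to give about 120 nM, most likely between 25 nM and 600 nM.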

Compound 3, half-maximal inhibitory concentration: 86 nM
Compound 3: middle estimate off by 1.4-fold (0.14 log units), on the high side, and the stated range covers the measured number.
By their numbers in this assay, from the lowest: compounds 2 and 3 (each within the scatter of the next); then compound 1.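

Replacing cyclopropyl with hexyl on this saturated chain carbon, two bonds along the chain from an aromatic carbon, gives a 58-fold lower number from compound 1 to compound 3 (1.76 log units; beyond the scatter) in this assay. Going by these compounds alone, this is the first pair of compounds that differ in this one place alone, so the large gain in inhibition can be tied to this change, not to other parts of the structure. The size of this single step shows that inhibition is highly sensitive to the group carried here, though no supporting data explain the gain.

From the compounds shown here alone, the step removes a ring and adds carbons at once, so it remains open which of the two matters, or whether both do. A propyl chain or a cyclohexyl group here would help separate them, and a decyl chain would test whether lengthening further still helps.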